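The source may hold more compounds than are shown below. What is called first, only, known or untested is meant among the compounds shown, and "the series" means these compounds.

Measured in a functional assay on SW480 cells (Homo sapiens) for antiproliferative activity, read by MTT assay, with a stated time of 48 h; a lower number here means a stronger inhibitor, a higher number a weaker inhibitor:
Compound 1 `CC(C)=CCC[C@]1(C)/C=C/[C@@H](OC(=O)C=C(C)C)[C@](C)(O)/C=C/C(=O)/C(CN2CCCC2)=C\C1`: 310 nM
Compound 2 `CC(C)=CCC[C@]1(C)/C=C/[C@@H](OC(=O)C=C(C)C)[C@](C)(O)/C=C/C(=O)/C(C[Si](C)(C)C(C)(C)C)=C\C1`: 3350 nM

Compound 2, at 3350 nM, holds the higher of the two numbers and is the weaker inhibitor of the pair. Compound 3 `CC(C)=CCC[C@]1(C)/C=C/[C@@H](OC(=O)C=C(C)C)[C@](C)(O)/C=C/C(=O)/C(C(=O)N(C)C)=C\C1` has not yet been measured. It differs from compound 2 by a group of 5 heavy atoms (3 carbon, 1 nitrogen, 1 oxygen; no ring) in place of a group of 8 heavy atoms (7 carbon, 1 silicon; no ring), on a double-bonded ring carbon, with the dimethylcarbamoyl on a double-bonded ring carbon. Going by the values given here, only one measured step bears on this: an 11-fold higher number from compound 1 to compound 2 (1.03 log units; beyond the scatter), a large step, made on a saturated chain carbon bound to a double-bonded ring carbon. Compound 3 gives up the silicon-bearing group, as compound 1 at 310 nM does, but the group it gains has no ring and sits on a different atom, so only a partial return towards compound 1 is expected. The expected move is to a lower number, a 3.4-fold lower number from compound 2 to compound 3 (0.53 log units; beyond the scatter). For compound 3 the estimate is 1000 nM, with an expected range of 300 nM to 3500 nM.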

Compound 3, half-maximal inhibitory concentration: 3300 nM
Compound 3: middle estimate off by 3.3-fold (0.52 log units), on the low side, and the stated range covers the measured number.
By their numbers in this assay, from the lowest: compound 1; then compounds 3 and 2 (each within the scatter of the next).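

In this assay, dimethylcarbamoyl in place of the silicon-bearing group on the double-bonded ring carbon gives a 1.0-fold lower number from compound 2 to compound 3 (0.01 log units; within the scatter), so the two groups cannot be told apart at this position. Giving up the silicon is therefore not enough to reach the number of compound 1: the step of an 11-fold higher number from compound 1 to compound 3 (1.03 log units; beyond the scatter) sets (pyrrolidin-1-yl)methyl apart from dimethylcarbamoyl, and it is the only one of the three groups that has a ring. Nothing measured here accounts for this difference.

The compounds shown leave open whether an open-chain amine such as (dimethylamino)methyl on this double-bonded ring carbon would stand with compound 1 or with compound 2 and compound 3. From the compounds shown here alone, how a carboxylic acid at the same place would read also remains open.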